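Amide variation on the shared core: compound 4 expected

This account rests on a few compounds, and the source may have more. Where it says the series, first, only, none or still open, it means among the compounds named here.

Compound 3, `CCn1c(C(=O)NC(CC(=O)O)C(=O)OC)ccc1C(CC)(CC)c1ccc(OCCC(O)(CC)CC)c(C)c1`, gives 26 nM in an assay on cells for agonist activity at vitamin D3 receptor (Homo sapiens), with a stated time of 96 h (on this read-out lower numbers stand for an effect already at smaller amounts and higher numbers for an effect only at larger amounts of compound), and holds the lowest of the two numbers; compound 2, `CCOc1ccc(NC(=O)c2ccc(C(CC)(CC)c3ccc(OCCC(O)(CC)CC)c(C)c3)n2CC)cc1`, gives 1630 nM, and the gap is a 63-fold lower number from compound 2 to compound 3 (1.80 log units; beyond the scatter). Compound 1, `CCn1c(C(=O)N(CCC#N)CCC#N)ccc1C(CC)(CC)c1ccc(OCCC(O)(CC)CC)c(C)c1`, reaches only the limit > 10000 nM in this assay. That limit is recorded as the limit of > 10000 nM in this assay, at which 1 of the 3 values shown sits.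

Compound 4, `CCn1c(C(=O)N(C)CCO)ccc1C(CC)(CC)c1ccc(OCCC(O)(CC)CC)c(C)c1`, carries a group of 5 heavy atoms (3 carbon, 1 nitrogen, 1 oxygen; no ring) in place of a group of 10 heavy atoms (5 carbon, 1 nitrogen, 4 oxygen; no ring), on a carbonyl carbon. Going by the values given here, two measured steps bear on this. From the tertiary amide of compound 1 to the acid-bearing secondary amide of compound 3 the change was an at least 380-fold lower number from compound 1 to compound 3 (2.58 log units; beyond the scatter); from the aryl amide of compound 2 it was a 63-fold lower number from compound 2 to compound 3 (1.80 log units; beyond the scatter). Compound 4 returns to a small tertiary amide without the carboxylic acid and ester, so a sizeable rise in number is expected in this assay, though not necessarily back to the limit seen for compound 1.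

The estimate for compound 4 is 2000 nM, between 300 nM and 12000 nM, an expected step of a 77-fold higher number from compound 3 to compound 4 (1.89 log units; beyond the scatter).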

Compound 4, half-maximal effective concentration: 52.7 nM
For compound 4 the middle estimate is 38-fold (1.58 log units) above the measured one; measured number outside the range, below it.
By their numbers in this assay, from the lowest: compound 3; then compound 4; then compound 2. At a limit, above all of these: compound 1.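

In this assay, the (2-hydroxyethyl)(methyl)amino group on the carbonyl carbon comes close to the much larger group it replaces, with a 2.0-fold higher number from compound 3 to compound 4 (0.31 log units; beyond the scatter), so a low number at this position does not require that group's carboxylic acid and methyl ester. The same small group also gives a 31-fold lower number from compound 2 to compound 4 (1.49 log units; beyond the scatter) against the (4-ethoxyphenyl)amino group, and an at least 180-fold lower number from compound 1 to compound 4 (2.27 log units; beyond the scatter), which shows that a tertiary amide at this position does not by itself bring a high number. Compound 1 remains a limit and not a number: the limit of > 10000 nM in this assay, at which 1 of the 4 values shown sits.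

The compounds shown do not separate the contribution of the hydroxyl from that of the rest of the (2-hydroxyethyl)(methyl)amino group. From the compounds shown here alone, how a longer chain ending in a hydroxyl, or an amine in the hydroxyl's place, would read at this position remains open.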